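Allylsulfanyl for aminoamino on a quinazoline-type core

This account rests on a few compounds, and the source may have more. Where it says the series, first, only, none or still open, it means among the compounds named here.

Measured compounds:
- compound 1, `Cc1ccc(C(=O)Nc2ccc(Cl)cc2C(N)=O)cc1`, 8.23 ug/mL
- compound 2, `Cc1ccc(-c2nc(NN)c3cc(Cl)ccc3n2)cc1`, 3.98 ug/mL
- compound 3, `Cc1ccc(-c2nc3ccc(Cl)cc3c(=O)n2N)cc1`, 12.1 ug/mL

Three compounds have been run in a functional assay on HeLa cells (Homo sapiens) for antiproliferative activity, read by MTT assay, with a stated time of 48 h; a higher number here means a weaker inhibitor, a lower number a stronger inhibitor. Compound 1 gives 8.23 ug/mL, compound 3 gives 12.1 ug/mL, and compound 2 gives 3.98 ug/mL. Compound 2 thus has the lowest number of the three, and both gaps lie beyond the scatter of repeated measurements: compound 1 is the nearest of the other two, compound 3 the furthest. Going by the values given here, none of these three differs from another in a single place, so no step between measured compounds can be drawn.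

The next compound, compound 4 `C=CCSc1nc(-c2ccc(C)cc2)nc2ccc(Cl)cc12`, is not yet measured. It differs from compound 2 in one place: allylsulfanyl in place of aminoamino on an aromatic carbon. The change removes both hydrogen-bond donors from that position and brings in a chain with a double bond outside the aromatic rings. Among the compounds with values here, nothing among the measured compounds shows what such an exchange does in this assay.

The author expects only a small shift in this assay, from compound 2 to compound 4 a step of a 1.6-fold higher number from compound 2 to compound 4 (0.21 log units; within the scatter), leaning toward a weaker inhibitor but possibly within the scatter. For compound 4 the estimate is 6.5 ug/mL, with a range from 2 ug/mL to 20 ug/mL.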

Compound 4, half-maximal inhibitory concentration: 9.66 ug/mL
For compound 4 the middle estimate is 1.5-fold (0.17 log units) below the measured one; measured number inside the range.
By their numbers in this assay, from the lowest: compound 2; then compounds 1, 4 and 3 (each within the scatter of the next).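

In this assay, placing allylsulfanyl where aminoamino stood on this aromatic carbon gives a 2.4-fold higher number from compound 2 to compound 4 (0.39 log units; beyond the scatter), the first single-place step available in the series, and it shows that the number responds to what sits at this position. The exchange does not remove the antiproliferative effect, since compound 4, which has no hydrogen-bond donors in this group, still gives 9.66 ug/mL. Nothing at hand accounts for the shift.

The compounds shown leave open which part of the exchange carries the step: the removal of the aminoamino group's hydrogen-bond donors, the sulfur, or the double bond outside the aromatic rings. Going by these compounds, a plain amine, a methylsulfanyl group, a saturated propylsulfanyl chain or an allyloxy group on the same carbon would each test one of these parts separately, and it also remains open whether the same exchange would give a step of similar size with a group other than the 4-methylphenyl on the shared core.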